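Trimming the Selenium Chain in a Cytotoxicity Series

The source may hold more compounds than are shown below. What is called first, only, known or untested is meant among the compounds shown, and "the series" means these compounds.

Compound 1 `CCCCC[Se]c1nc(NCc2ccccc2)c2ccccc2n1` and compound 3 `C[Se]c1nc(NCc2ccccc2)c2ccccc2n1` share one core and differ only by hydrogen in place of butyl on a saturated chain carbon bound to a selenium atom. In an ADME assay on BEAS-2B cells (Homo sapiens) for cytotoxicity, read by MTT assay, with a stated time of 72 h (on this read-out lower numbers stand for stronger inhibition of growth and higher numbers for weaker inhibition of growth), compound 1 gives 44100 nM, whereas compound 3 gives 570 nM, so that a 77-fold lower number from compound 1 to compound 3 (1.89 log units; beyond the scatter). Compound 2 `CCCCC[Se]c1nc(N)c2cccnc2n1` is built on another core; the difference between the two cores is not broken down here. In this assay compound 2 gives 16300 nM. Compound 4 `C[Se]c1nc(N)c2cccnc2n1` stands to compound 2 as compound 3 stands to compound 1: the change is hydrogen in place of butyl on a saturated chain carbon bound to a selenium atom, the same change at the same place, occurring twice among these four compounds. Because the measured step of a 77-fold lower number from compound 1 to compound 3 (1.89 log units; beyond the scatter) is large, a step of similar size is expected here, a 54-fold lower number from compound 2 to compound 4 (1.74 log units; beyond the scatter), though it rests on a single measured pair. Compound 4 is therefore estimated at 300 nM, with a likely range from 60 nM to 1500 nM.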

Compound 4, concentration for 50% growth inhibition: 39700 nM
Compound 4: the middle estimate sits 130-fold (2.12 log units) below what was measured; measured number above the stated range.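

In this assay, hydrogen in place of butyl on a saturated chain carbon bound to a selenium atom gives a 2.4-fold higher number from compound 2 to compound 4 (0.39 log units; beyond the scatter), so on this core the number moves in the opposite direction. The change therefore does not carry over between these two cores in either size or direction, and its outcome depends on the core that bears it: the same change on two cores in this assay, a 77-fold lower number (1.89 log units; beyond the scatter) from compound 1 to compound 3 and a 2.4-fold higher number (0.39 log units; beyond the scatter) from compound 2 to compound 4, 190-fold (2.28 log units) apart, beyond the scatter of two such steps. Within the data shown here, with only two matched pairs, this does not show which part of the cores is responsible or how the change would behave on a third core.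

Going by these compounds, it remains open how intermediate chains, such as ethyl or propyl, would behave on each core. These could show whether the number shifts gradually or abruptly as the chain shortens.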